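Ester swap on a kinase inhibitor: phenyl to cyclopropylmethyl

The compounds below may be only part of what the source reports. "The series", "measured", "known", "first", "only" and "open" are said of these compounds alone.

Measured so far:
compound 1 `CCOC(=O)c1cccc(-c2cc(C(=O)Nc3ccncc3)ccc2CN)c1`, < 1 nM
compound 2 `NCc1ccc(C(=O)Nc2ccncc2F)cc1-c1cccc(C(=O)Oc2ccccc2)c1`, 6.2 nM

In an assay on isolated protein for inhibition of Rho-associated protein kinase 2 (Homo sapiens), read by radiometric assay (on this read-out higher numbers stand for weaker inhibition and lower numbers for stronger inhibition), compound 1 gives only a limit, < 1 nM, so it yields no number. In this assay, for the measured compounds named here, compound 2 gives 6.2 nM, the only actual number in the set. Compound 3 `NCc1ccc(C(=O)Nc2ccncc2F)cc1-c1cccc(C(=O)OCC2CC2)c1` differs from compound 2 by cyclopropylmethyl in place of phenyl on an oxygen next to a carbonyl group. Going by the values given here, no measured pair shows such a step, so its size is unknown. Compound 3 is expected to change by a 1.5-fold higher number from compound 2 to compound 3 (0.16 log units; within the scatter), a step within the scatter or slightly weaker. Compound 3 is estimated at 9 nM, between 2.5 nM and 30 nM.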

Compound 3, half-maximal inhibitory concentration: 2.7 nM
Estimate against measurement, compound 3: 3.3-fold (0.52 log units) above; low and high end bracket the measured number.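

In this assay, for the compounds shown here, the swap gives the first readable step at this position: a 2.3-fold lower number from compound 2 to compound 3 (0.36 log units; beyond the scatter). The group on an oxygen next to a carbonyl group therefore need not be aromatic, as cyclopropylmethyl is accepted here and gives modestly stronger inhibition than phenyl. Compound 1 differs from these compounds in more than one place and gives only a limit, so it adds no step: the limit of < 1 nM in this assay, at which 1 of the 3 values shown sits.

Going by these compounds, whether an ethyl group on this oxygen would match cyclopropylmethyl on the core of compound 3 stays open. So does the effect of replacing the ester with a carboxylic acid or an amide.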